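Changing the Aryl Group on the Shared Core

The compounds below may be only part of what the source reports. "The series", "measured", "known", "first", "only" and "open" are said of these compounds alone.

Compound 1 `COc1ccc(-n2nncc2CN2C(=O)C3(C(C#N)=C(N)Oc4c(N)cc5nc6ccccc6nc5c43)c3ccccc32)cc1` was measured in an ADME assay on HUVEC cells (Homo sapiens) for antiproliferative activity, read by MTT assay, with a stated time of 48 h (a lower number here means a stronger inhibitor, a higher number a weaker inhibitor), and gives > 50000 nM, which is a limit of the assay and not a number. Compound 2 `N#CC1=C(N)Oc2c(N)cc3nc4ccccc4nc3c2C12C(=O)N(Cc1cnnn1-c1ccc([N+](=O)[O-])cc1)c1ccccc12` gives > 50000 nM in this assay, again a limit rather than a number. Compound 3 `Cc1ccc(Cl)cc1-n1nncc1CN1C(=O)C2(C(C#N)=C(N)Oc3c(N)cc4nc5ccccc5nc4c32)c2ccccc21` gives > 50000 nM in this assay, also a limit.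

Compound 3 therefore does not stand at a readable point: its value is a limit, and the two further values shown are limits as well (the limit of > 50000 nM in this assay, at which 3 of the 3 values shown sit). The unmeasured compound 4 `COc1cc(-n2nncc2CN2C(=O)C3(C(C#N)=C(N)Oc4c(N)cc5nc6ccccc6nc5c43)c3ccccc32)c(OC)cc1Cl` carries the change (4-chloro-2,5-dimethoxyphenyl in place of 5-chloro-2-methylphenyl on an aromatic nitrogen). Among the measured compounds shown here, two measured steps touch the same position, from compound 2 to compound 3 a step that the two limits leave unreadable from compound 2 to compound 3 and from compound 1 to compound 3 a step that the two limits leave unreadable from compound 1 to compound 3, and both are left unreadable because all three values sit at the limit (the limit of > 50000 nM in this assay, at which 3 of the 3 values shown sit). Nothing measured shows that exchanging one aryl group for another at this nitrogen brings the value below the limit, so no readable step is expected in this assay; the step from compound 3 to compound 4 is estimated as a step that the limit leaves unreadable from compound 3 to compound 4. Compound 4 is expected to give 60000 nM, within a range from 20000 nM to 200000 nM, most likely reported again only as a limit.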

Compound 4, half-maximal inhibitory concentration: > 50000 nM
Compound 4: a limit, no number; the forecaster's own chance of this, stated with the estimate: 85%; the middle value is on the limit's open side.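

In this assay compound 4 gives > 50000 nM as a limit and not a number. Its steps to compound 1, compound 2 and compound 3 cannot be read, because every value sits at the same limit: the limit of > 50000 nM in this assay, at which 4 of the 4 values shown sit.

The compounds shown leave open whether any aryl group at this nitrogen gives a readable value in this assay and, if so, which one.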